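This account rests on a few compounds, and the source may have more. Where it says the series, first, only, none or still open, it means among the compounds named here.

Measured compounds:
Compound 1, `Cc1nc(C(C)C)n2c(O)nnc(-c3ccccc3)c12` — in a functional assay for inhibition, with Homo sapiens as the target (a lower number here means a stronger inhibitor, a higher number a weaker inhibitor), compound 1 gives > 48000 nM, which is a limit of the assay.
Compound 2, `CSc1nnc(-c2ccccc2)c2c(C)nc(C(C)C)n12` — in this assay compound 2 gives > 48000 nM, again a limit.
Compound 3, `CCc1nc(C)c2c(-c3ccccc3)nnc(O)n12` — in this assay compound 3 gives > 48000 nM, again a limit.

Compound 1 stands only at the limit in this assay, and no number is known for it or for any other compound shown (the limit of > 48000 nM in this assay, at which 3 of the 3 values shown sit). Compound 4, `Cc1nc(C(C)C)n2c(O)nncc12`, differs from compound 1 by hydrogen in place of phenyl on an aromatic carbon. Among the measured compounds shown here, the only measured steps around compound 1, a step that the two limits leave unreadable from compound 1 to compound 2 and a step that the two limits leave unreadable from compound 1 to compound 3, have no readable size, so they give no direction for the step to compound 4. Nothing in the values shown points to a gain. Compound 4 is therefore expected to stay at the limit, estimated at 80000 nM (30000 nM to 300000 nM). The step that the limit leaves unreadable from compound 1 to compound 4 is expected to be none that can be read.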

Compound 4, half-maximal inhibitory concentration: > 48000 nM
Compound 4 gave a limit, no number; the forecaster's own chance of this, stated with the estimate: 90%; the middle value is on the limit's open side.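

No step can be read between compound 1 and compound 4: both values are limits, not numbers. Whether the phenyl of compound 1 matters for inhibition, and how far any compound shown lies past the limit, stays open.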